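The source may hold more compounds than are shown below. What is called first, only, known or untested is meant among the compounds shown, and "the series" means these compounds.

Compound 1 `CCOC(=O)CNC(=O)NC1=CS(=O)(=O)O[C@@]12[C@@H](CO[Si](C)(C)C(C)(C)C)O[C@@H](n1cc(C)c(=O)n(C)c1=O)[C@@H]2O[Si](C)(C)C(C)(C)C`: 16000 nM
Compound 2 `COC(=O)CNC1=CS(=O)(=O)O[C@@]12[C@@H](CO[Si](C)(C)C(C)(C)C)O[C@@H](n1cc(C)c(=O)n(C)c1=O)[C@@H]2O[Si](C)(C)C(C)(C)C`: >= 400000 nM (a limit)
Compound 3 `Cc1cn([C@@H]2O[C@H](CO[Si](C)(C)C(C)(C)C)[C@@]3(OS(=O)(=O)C=C3NC(=O)NC(=O)c3ccccc3)[C@H]2O[Si](C)(C)C(C)(C)C)c(=O)n(C)c1=O`: >= 80000 nM (a limit)

Of the compounds shown here, three have been tested in a functional assay on HEL cells (Homo sapiens) for cytotoxicity, read by microscopy; a higher number here means that more compound is tolerated, a lower number that less compound is tolerated. Compound 1 gives 16000 nM as a number. Compound 2 reaches only a limit of this assay, >= 400000 nM (the limit of >= 400000 nM in this assay, at which 1 of the 3 values shown sits). Compound 3 likewise stops at a limit, >= 80000 nM (the limit of >= 80000 nM in this assay, at which 1 of the 3 values shown sits). Compound 2 therefore stands at the top of what has been measured: the step of an at least 25-fold higher number from compound 1 to compound 2 (1.39 log units; beyond the scatter) is beyond the scatter, while the step that the two limits leave unreadable from compound 2 to compound 3 cannot be read because both ends are limits.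

Compound 4 `Cc1cn([C@@H]2O[C@H](CO[Si](C)(C)C(C)(C)C)[C@@]3(OS(=O)(=O)C=C3NCC(=O)C(=O)O)[C@H]2O[Si](C)(C)C(C)(C)C)c(=O)n(C)c1=O` differs from compound 2 by carboxy in place of methoxy on a carbonyl carbon. Going by the values given here, no measured pair swaps a methoxy for a carboxy, so only the step of an at least 25-fold higher number from compound 1 to compound 2 (1.39 log units; beyond the scatter) bears on it, and it shows that the (methoxycarbonyl)methyl-bearing compound 2 is already tolerated up to the limit. The step of an at least 5.0-fold higher number from compound 1 to compound 3 (0.69 log units; beyond the scatter) is at least modest but concerns a different nitrogen. Compound 4 is therefore expected to stay at the limit as well, with an expected step of a number no higher from compound 2 to compound 4 (the limit leaves the size open) showing nothing beyond the scatter. The estimate for compound 4 is 400000 nM, in a range from 100000 nM to 800000 nM.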

Compound 4, minimum cytotoxic concentration: 400000 nM
Beside the measured number, compound 4's estimate shows no gap at the digits printed; measured number inside the range.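

In this assay, compound 4 is the first compound shown with a carboxy on this carbonyl carbon, and it gives a plain number, not a limit. Carboxy in place of methoxy on this carbonyl carbon gives a number no higher from compound 2 to compound 4 (the limit leaves the size open). Putting (carboxycarbonyl)methyl in place of ((ethoxycarbonyl)methyl)carbamoyl on the amine nitrogen gives a 25-fold higher number from compound 1 to compound 4 (1.40 log units; beyond the scatter). Compound 2 and compound 3 each stand at a limit, so the size of the step from compound 2 and the step from compound 3 to compound 4 cannot be read, and any difference between carboxy and methoxy on this carbonyl carbon stays hidden.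

The compounds shown leave open how an amide on this carbonyl carbon, a longer chain on the amine nitrogen, or free hydroxyl groups in place of the tert-butyldimethylsilyl groups would read. No measurement shown speaks to what lies behind the tolerance of compound 4.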